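Swapping Fluoro for Dimethylamino on a Shared Core

A few compounds are considered here, and "the series" means these few. Any claim that something is new, unique, unknown or untested is made for them only; others in the source may bear on it.

In a physicochemical assay for lipophilicity, read by HPLC, at pH 7.5 (on this read-out higher numbers stand for higher lipophilicity and lower numbers for lower lipophilicity), compound 1, `CC[C@@H](Nc1c(C#N)c(-c2ccc(-c3ccccc3F)cc2)nc2cnccc12)C(N)=O`, gives 2.7.
In this assay compound 2, `CCOc1ccccc1-c1ccc(-c2nc3cnccc3c(N[C@H](CC)C(=O)N(C)C)c2C#N)cc1`, gives 3.7.
In this assay compound 3, `CCOc1ccccc1-c1ccc(-c2nc3cnccc3c(C[C@H](C)C(=O)O)c2C#N)cc1`, gives 2.2.

Among these three numbers compound 1 stands second highest: compound 3 lies lower, beyond the scatter, and compound 2 lies higher, also beyond the scatter. Among the compounds with values here, only one pair of measured compounds differs in a single place, and that step is a number 1.50 log units lower from compound 2 to compound 3 (beyond the scatter), a large drop.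

The unmeasured compound 4, `CC[C@@H](Nc1c(C#N)c(-c2ccc(-c3ccccc3N(C)C)cc2)nc2cnccc12)C(N)=O`, differs from compound 1 in one place: dimethylamino in place of fluoro on an aromatic carbon. Within the data shown here, no measured step involves this position or either of these two groups. Among the measured compounds shown here, the one available step, a number 1.50 log units lower from compound 2 to compound 3 (beyond the scatter), concerns a different part of the shared core, so it offers no direct guide to what a change at the aryl position does. What remains is the counted difference: a single fluorine leaves and three heavy atoms enter, with one hydrogen-bond acceptor among them.

On that basis alone a modest rise in this assay is expected, a number 0.30 log units higher from compound 1 to compound 4 (within the scatter), and compound 4 is estimated at 3, within a range from 2.5 to 3.5.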

Compound 4, distribution coefficient: 3.2
Estimate against measurement, compound 4: 0.20 log units below; low and high end bracket the measured number.
By their numbers in this assay, from the lowest: compound 3; then compound 1; then compound 4; then compound 2.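

In this assay, within the data shown here, the change from 2-fluorophenyl to 2-(dimethylamino)phenyl, on an aromatic carbon ortho to a large group, is a number 0.50 log units higher from compound 1 to compound 4 (beyond the scatter) and so gives the first reading at this position: the number here does respond to the group carried, and by more than repeated measurements would scatter. Among these compounds, until now the only step between measured compounds lay at a different place on the shared core, so this pair is the sole evidence about the aryl position, and it rests on one swap of one group for another on one background. Nothing among the data shown explains why the number moves in this direction or by this amount.

The compounds shown leave open whether a plain amino group, a hydroxyl group or the longer diethylamino group at the same place would raise the number, lower it or leave it unchanged. They also leave open whether the swap from fluoro to dimethylamino would give a step of similar size on a compound with a different side chain on the shared core.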